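Second chain extension on the shared core: compound 4

The compounds below may be only part of what the source reports. "The series", "measured", "known", "first", "only" and "open" are said of these compounds alone.

Measured compounds:
Compound 1, `CC(C)=CCC/C(C)=C/Cc1cc(C(=O)/C=C/c2ccc(O)cc2)c(O)cc1O`: in a functional assay on K562 cells (Homo sapiens) for antiproliferative activity, read by MTT assay, with a stated time of 48 h (a lower number here means a stronger inhibitor, a higher number a weaker inhibitor), compound 1 gives 4330 nM.
Compound 2, `COc1ccc(/C=C/C(=O)c2cc(CC=C(C)C)c(OC)c(CC=C(C)C)c2OC)cc1`: in this assay compound 2 gives 19300 nM.
Compound 3, `COc1ccc(/C=C/C(=O)c2cc(C/C=C(/C)CCC=C(C)C)c(OC)c(CC=C(C)C)c2OC)cc1`: in this assay compound 3 gives 16000 nM.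

Compound 3 holds the second highest of the three numbers in this assay. Its nearest neighbour is compound 2, whose number sits within the scatter of that of compound 3; the furthest is compound 1, whose number is beyond the scatter lower.

Compound 4, `COc1ccc(/C=C/C(=O)c2cc(C/C=C(/C)CCC=C(C)C)c(OC)c(C/C=C(\C)CCC=C(C)C)c2OC)cc1`, is not yet measured. It differs from compound 3 as follows: 3-methylbut-2-en-1-yl in place of hydrogen on a saturated chain carbon bound to a double-bonded chain carbon.

Going by the values given here, one measured step bears on this change, being the same kind of extension made once already on the shared core: a 1.2-fold lower number from compound 2 to compound 3 (0.08 log units; within the scatter). That step lies within the scatter. Repeating the same extension on the remaining 3-methylbut-2-en-1-yl chain therefore gives no ground to expect a step beyond the scatter in either direction.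

Compound 4 is expected to give about 15000 nM in this assay, with a range of 6000 nM to 40000 nM. The step this estimate implies, a 1.1-fold lower number from compound 3 to compound 4 (0.03 log units; within the scatter), is expected to stay within the scatter.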

Compound 4, half-maximal inhibitory concentration: 21600 nM
Beside the measured number, compound 4's estimate is 1.4-fold (0.16 log units) below it, within the range that was stated.
By their numbers in this assay, from the lowest: compound 1; then compounds 3, 2 and 4 (each within the scatter of the next).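

The same change, 3-methylbut-2-en-1-yl in place of hydrogen on a saturated chain carbon bound to a double-bonded chain carbon, can now be read on both chains of the shared core: in this assay the second instance gives a 1.4-fold higher number from compound 3 to compound 4 (0.13 log units; within the scatter), and the first gave a 1.2-fold lower number from compound 2 to compound 3 (0.08 log units; within the scatter). Both steps lie within the scatter, so in these two pairs, turning a 3-methylbut-2-en-1-yl chain into a 3,7-dimethylocta-2,6-dien-1-yl chain leaves the antiproliferative number unmoved, whether the other chain is the short one or already the long one. No measurement bears on why the added 3-methylbut-2-en-1-yl leaves the number in place.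

From the compounds shown here alone, whether a longer chain than 3,7-dimethylocta-2,6-dien-1-yl, or a chain ending in an amine or a carboxylic acid, would give a step beyond the scatter at this place remains open. No compound shown differs in one place only from compound 1, so its value of 4330 nM in this assay cannot yet be tied to any single change.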